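Chloro for Methoxy on the Aryl Ring of Compound 2

The source may hold more compounds than are shown below. What is called first, only, known or untested is meant among the compounds shown, and "the series" means these compounds.

Compound 2 `CCCc1nc(-c2ccccc2)c(CNCCN2CCN(c3cccc(OC)c3)CC2)o1` is the starting point here. In an assay on HEK293 cells for inhibition of Voltage-dependent T-type calcium channel subunit alpha-1G (Homo sapiens), read by fluorescence, tested at 10 uM (on this read-out higher numbers stand for more inhibition at the one concentration tested (going by the name of the read-out) and lower numbers for less inhibition), compound 2 gives 40.2%. Among the three compounds measured so far this is the lowest number, though compound 3 `CCCc1nc(-c2ccccc2)c(CNCCCN2CCN(c3ccccc3)CC2)o1`, with 43.7%, lies within the scatter of it, so the two cannot be ordered. Compound 1 `CCCc1nc(-c2ccccc2)c(CNCCN2CCN(c3ccccc3Cl)CC2)o1` stands furthest away with 60.1%.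

The change to compound 4 `CCCc1nc(-c2ccccc2)c(CNCCN2CCN(c3cccc(Cl)c3)CC2)o1` is chloro in place of methoxy on an aromatic carbon. Going by the values given here, the only measured step that touches this part of the molecule is a number 19.9 percentage points lower from compound 1 to compound 2 (beyond the scatter); that step exchanged both the kind of group and its place on the ring, so it bears only loosely on the present change, which keeps the place and exchanges methoxy for chloro. Among the compounds with values here, no step links compound 3 to compound 2, so its value says nothing more than where it sits. Within the data shown here, the one relevant step shows a chlorine-bearing ring scoring higher than a methoxy-bearing one, so a modest rise is expected: a number 11.8 percentage points higher from compound 2 to compound 4 (beyond the scatter). Compound 4 is therefore estimated at 52%, within a range from 33% to 70%.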

Compound 4, a percentage reported as inhibition, at one concentration (the size of the read-out at that concentration, not a potency): 51.2%
Compound 4: the middle estimate sits 0.8 percentage points above what was measured, within the range that was stated.
By their numbers in this assay, from the lowest: compounds 2, 3, 4 and 1 (each within the scatter of the next, the first and the last beyond it).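

With the place on the ring held fixed, the exchange of methoxy for chloro can now be read on its own: in this assay it gives a number 11 percentage points higher from compound 2 to compound 4 (beyond the scatter) and so separates the two groups by more than repeat measurements would. The 3-chlorophenyl group in place of 2-chlorophenyl gives a number 8.9 percentage points lower from compound 1 to compound 4 (within the scatter) and this step stays inside the scatter, so these two chlorine-bearing compounds cannot be put in order. The earlier step from compound 1 to compound 2 changed the group and its place together, whereas these two new steps take those changes one at a time, and only the change of group is large enough to be read here, while no measurement at hand offers a reason for either result.

What the compounds shown leave open is how other groups at this place would score, such as a fluoro, a methyl, a nitrile or an amine, and whether any of them would go beyond the number for compound 4. A single reading at one concentration also leaves open how potent any of these compounds is, so a full concentration series for compound 2 and compound 4 would be needed to say how far apart they truly stand.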